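Pyrrolidine for Chlorophenoxy on the Pyrazole Core

The source may report more compounds than this note shows. Statements on the series, on what has been measured and on what is new or still open speak of the compounds shown alone.

Compound 2 `Cc1nn(C)c(Oc2ccc(Cl)cc2)c1/C=N/OCc1ccc(C(=O)OC(C)(C)C)cc1` gives the lowest number of the two measured, 0.28 ug/mL in a functional assay on SK-OV-3 cells (Homo sapiens) for cytotoxicity (a higher number here means a weaker inhibitor, a lower number a stronger inhibitor), with compound 1 `Cc1nn(C)c(-n2cccc2)c1/C=N/OCc1ccc(C(=O)OC(C)(C)C)cc1` at 3.91 ug/mL. Compound 3 `Cc1nn(C)c(N2CCCC2)c1/C=N/OCc1ccc(C(=O)OC(C)(C)C)cc1` differs from compound 2 by pyrrolidin-1-yl in place of 4-chlorophenoxy on an aromatic carbon. Among the measured compounds shown here, the only step that bears on this is a 14-fold lower number from compound 1 to compound 2 (1.15 log units; beyond the scatter), where the 4-chlorophenoxy replaced another five-membered nitrogen ring; compound 3 returns to such a ring, so a step back toward compound 1 is expected. Compound 3 is estimated at 2 ug/mL, within 0.5 ug/mL to 8 ug/mL, an expected 7.1-fold higher number from compound 2 to compound 3 (0.85 log units; beyond the scatter).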

Compound 3, half-maximal inhibitory concentration: 3.19 ug/mL
Compound 3: middle estimate off by 1.6-fold (0.20 log units), on the low side, and the stated range covers the measured number.
By their numbers in this assay, from the lowest: compound 2; then compounds 3 and 1 (each within the scatter of the next).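

In this assay, moving to pyrrolidin-1-yl at this aromatic carbon costs a large step (an 11-fold higher number from compound 2 to compound 3 (1.06 log units; beyond the scatter)), so the low number of compound 2 does not survive this change. The non-aromatic pyrrolidin-1-yl and the aromatic 1H-pyrrol-1-yl are not told apart here (a 1.2-fold lower number from compound 1 to compound 3 (0.09 log units; within the scatter)), which leaves compound 1 and compound 3 together, both apart from compound 2. Nothing available explains this difference.

The compounds shown leave open whether the ether oxygen, the phenyl ring or the chlorine of 4-chlorophenoxy carries the low number. Unsubstituted phenoxy or 4-chloroanilino at this carbon would separate these parts.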